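The source may report more compounds than this note shows. Statements on the series, on what has been measured and on what is new or still open speak of the compounds shown alone.

Working notes on the series, read in a functional assay on HEL cells (Homo sapiens) for cytotoxicity; on this read-out higher numbers stand for lower toxicity in this test and lower numbers for higher toxicity in this test. Compound 1 `CCCCC#Cc1cc2cn(C)c(=O)nc2o1` gives > 217000 nM, which is a limit. Compound 2 `CCCCCCCCCCC#Cc1cc2cn(C)c(=O)nc2o1` gives > 150000 nM, also a limit. Within the data shown here, compound 3 `CCCCCCCCCCC#Cc1cc2cn([C@@H]3O[C@H](CO)[C@@H](O)[C@@H]3O)c(=O)nc2o1` gives 116000 nM, the only true number so far. Next comes compound 4 `CCCCCCCCCCC#Cc1cc2cn([C@H]3C[C@H](O)[C@@H](CO)O3)c(=O)nc2o1`, with hydrogen in place of hydroxy on a saturated ring carbon. Among the measured compounds shown here, two measured steps bear on this only loosely. Lengthening the chain gives a step that the two limits leave unreadable from compound 1 to compound 2. Changing the group on the aromatic nitrogen, the same substituent that now changes again, gives an at least 1.2-fold lower number from compound 2 to compound 3 (0.11 log units; that floor lies within the scatter). For the measured compounds named here, with only that floor as a guide, the expected change is a 1.2-fold lower number from compound 3 to compound 4 (0.06 log units; within the scatter), which means no step beyond the scatter in this assay. For compound 4 the estimate is 100000 nM, with an expected range of 45000 nM to 220000 nM.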

Compound 4, half-maximal cytotoxic concentration: 36000 nM
Compound 4: middle estimate off by 2.8-fold (0.44 log units), on the high side; the measured number lies below the stated range.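

In this assay, among these compounds, hydrogen in place of hydroxy on the saturated ring carbon gives a 3.2-fold lower number from compound 3 to compound 4 (0.51 log units; beyond the scatter) and so is the first change at this ring carbon that reads beyond the scatter. Against the limit of compound 2, the 4-hydroxy-5-(hydroxymethyl)oxolan-2-yl group on the aromatic nitrogen gives an at least 4.1-fold lower number from compound 2 to compound 4 (0.61 log units; beyond the scatter) and so also reads beyond the scatter. No measured property given here accounts for either step.

Going by these compounds, whether an amine or a fluorine on this ring carbon would read like hydrogen or like hydroxy stays open. So does the effect of this change on a shorter chain.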